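Phenoxy-to-chloro swap on a thiazolone series

The source may report more compounds than this note shows. Statements on the series, on what has been measured and on what is new or still open speak of the compounds shown alone.

Measured compounds:
compound 1, `O=C1N=C(c2ccc(Oc3ccccc3)cc2)S/C1=C\c1ccc(Oc2ccccc2)cc1`, 650 nM
compound 2, `COc1ccc(/C=C2\SC(c3ccc(Oc4ccccc4)cc3)=NC2=O)c2ccccc12`, 2150 nM
compound 3, `O=C1N=C(c2ccc(Cl)cc2)S/C1=C\c1ccc(Oc2ccccc2)cc1`, 170 nM

All three were measured in an assay on cells for inhibition of Polyunsaturated fatty acid 5-lipoxygenase (Homo sapiens), read by HPLC, with stated times of 15 min and 10 min; a higher number here means a weaker inhibitor, a lower number a stronger inhibitor. Compound 2 gives the highest number of the three; its nearest neighbour is compound 1 and the furthest is compound 3. The difference between the core of compound 1 and the core of compound 2 is not broken down here.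

The change chloro in place of phenoxy on an aromatic carbon gave a 3.8-fold lower number from compound 1 to compound 3 (0.58 log units; beyond the scatter). The same change is now made on compound 2, (chloro in place of phenoxy on an aromatic carbon), to give compound 4, `COc1ccc(/C=C2\SC(c3ccc(Cl)cc3)=NC2=O)c2ccccc12`, not yet measured in this assay.

Going by the values given here, for compound 4 a step of about a 3.6-fold lower number from compound 2 to compound 4 (0.55 log units; beyond the scatter) is expected, resting on the step from compound 1 to compound 3 in this assay, which was the only example of this change, so the estimate carries that uncertainty.

Compound 4 is estimated at 600 nM, with a likely range from 250 nM to 1500 nM.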

Compound 4, half-maximal inhibitory concentration: 640 nM
Compound 4: the middle estimate sits 1.1-fold (0.03 log units) below what was measured; the range from low to high includes it.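

In this assay, chloro in place of phenoxy on an aromatic carbon gives a 3.4-fold lower number from compound 2 to compound 4 (0.53 log units; beyond the scatter), and the size of the step carries over from one core to the other: the same change on two cores in this assay, a 3.8-fold lower number (0.58 log units; beyond the scatter) from compound 1 to compound 3 and a 3.4-fold lower number (0.53 log units; beyond the scatter) from compound 2 to compound 4, 1.1-fold (0.06 log units) apart, within the scatter of two such steps.

This agreement rests on two pairs only, so it supports carrying the change between these two cores but sets no rule for the wider series. It also does not show why the step has this size.

Still open, going by these compounds, is whether the step holds on a third core. Also open, on these data alone, is how a fluoro, an amine or a carboxylic acid would compare with chloro and phenoxy at this place.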